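A few compounds are considered here, and "the series" means these few. Any claim that something is new, unique, unknown or untested is made for them only; others in the source may bear on it.

Series notes, inhibition in a functional assay on J774.1 cells (Mus musculus) for inhibition, read by Griess assay; a higher number here means a weaker inhibitor, a lower number a stronger inhibitor:

compound 1 `CCCCCCCCCCS(=O)(=O)NCCCN(CCCNCCCCNCCCN)CCCNS(=O)(=O)CCCCCCCCCC` gives 1100 nM
compound 2 `CCCCCCCCCCCCS(=O)(=O)NCCCN(CCCNCCCCNCCCN)CCCNS(=O)(=O)CCCCCCCCCCCC` gives 2270 nM
compound 3 `CCCCCCCCCCS(=O)(=O)NCCCN(CCCNCCCNCCCCNCCCN)CCCNS(=O)(=O)CCCCCCCCCC` gives 430 nM

Compound 2 shows the highest number of the three in this assay, with compound 1 nearest and compound 3 furthest from it; both gaps are beyond the scatter. Compounds 1 and 3 share a core and differ in one place: (4-((3-aminopropyl)amino)butyl)amino in place of ((3-aminopropyl)amino)methyl on a saturated chain carbon, three bonds along the chain from an amine nitrogen. This change gave a 2.6-fold lower number from compound 1 to compound 3 (0.41 log units; beyond the scatter), a modest step toward stronger inhibition.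

Compound 4 `CCCCCCCCCCCCS(=O)(=O)NCCCN(CCCNCCCNCCCCNCCCN)CCCNS(=O)(=O)CCCCCCCCCCCC` is not yet measured in this assay. It relates to compound 2 by the same change, ((4-((3-aminopropyl)amino)butyl)amino in place of ((3-aminopropyl)amino)methyl on a saturated chain carbon, three bonds along the chain from an amine nitrogen), the place being the same word for word. The difference between the core of compound 2 and the core of compound 1 is not broken down here.

For the measured compounds named here, on the single precedent, the step expected from compound 2 to compound 4 is a 2.5-fold lower number from compound 2 to compound 4 (0.40 log units; beyond the scatter), resting on a 2.6-fold lower number from compound 1 to compound 3 (0.41 log units; beyond the scatter) seen for the same change. That it transfers to the core of compound 2 is unverified, so the range is kept wide. For compound 4 the estimate in this assay is 900 nM, expected to fall between 450 nM and 1800 nM.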

Compound 4, half-maximal inhibitory concentration: 510 nM
The estimate for compound 4 lay 1.8-fold (0.25 log units) above the measured number; the measured number falls inside the stated range.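

In this assay, putting (4-((3-aminopropyl)amino)butyl)amino in place of ((3-aminopropyl)amino)methyl on a saturated chain carbon, three bonds along the chain from an amine nitrogen, gave a 4.5-fold lower number from compound 2 to compound 4 (0.65 log units; beyond the scatter). The change lowers the number on both cores, and the two steps do not differ beyond what repeated measurement allows: the same change on two cores in this assay, a 2.6-fold lower number (0.41 log units; beyond the scatter) from compound 1 to compound 3 and a 4.5-fold lower number (0.65 log units; beyond the scatter) from compound 2 to compound 4, 1.7-fold (0.24 log units) apart, within the scatter of two such steps

In this series the change therefore carries from the core of compound 1 to the core of compound 2 as a step in the same direction and of comparable size, but this rests on two pairs only and shows neither why the number falls nor that the step would hold on any other core.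

On these data alone, whether the same step holds with a shorter or longer alkyl chain on the sulfonyl groups, or with a carboxamide in place of the sulfonamide, remains open. Also open, as far as these compounds go, is how the number responds to a longer polyamine chain or to a guanidine in place of the terminal primary amine.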